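Working notes: from compound 2 to compound 3

The source may report more compounds than this note shows. Statements on the series, on what has been measured and on what is new or still open speak of the compounds shown alone.

In a functional assay on HCT-116 cells (Homo sapiens) for antiproliferative activity, read by MTT assay, with a stated time of 48 h (a higher number here means a weaker inhibitor, a lower number a stronger inhibitor), compound 1 (`COc1cc(-c2nnc3c(OC4CN(C(C)(C)C)C4)cc(-c4ccc5[nH]ccc5c4)cn23)cc(OC)c1OC`) gives > 10000 nM and this is a limit of the assay, not a number. Compound 2 (`COc1cc(-c2nnc3c(OC)cc(-c4ccc5[nH]cc(C=O)c5c4)cn23)cc(OC)c1OC`) gives > 10000 nM and this too is only a limit.

Compound 3 (`COc1cc(-c2nnc3c(OC)cc(-c4ccc5c(ccn5C)c4)cn23)cc(OC)c1OC`) carries 1-methyl-1H-indol-5-yl in place of the 3-formyl-1H-indol-5-yl of compound 2, on an aromatic carbon of the shared core (1-methyl-1H-indol-5-yl in place of 3-formyl-1H-indol-5-yl on an aromatic carbon).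

Within the data shown here, no measured step is available. The expectation rests on the structural change alone, and compound 2 offers only its limit of > 10000 nM as a starting point. In this assay the expected direction is toward stronger inhibition, with the expected size given by an at least 6.6-fold lower number from compound 2 to compound 3 (0.82 log units; beyond the scatter) and known only loosely. For compound 3 the estimate is 1500 nM with an expected range from 60 nM to 10000 nM and a result at the limit remains possible.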

Compound 3, half-maximal inhibitory concentration: 33 nM
Beside the measured number, compound 3's estimate is 45-fold (1.66 log units) above it; measured number below the stated range.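

In this assay, the group on this aromatic carbon of the shared core separates a compound held at the assay limit from one with a measured potency: an at least 300-fold lower number from compound 2 to compound 3 (2.48 log units; beyond the scatter). Compound 3 is the only compound shown that gives a number rather than a limit, which ties 1-methyl-1H-indol-5-yl at this position to measurable inhibition. The step gives only a minimum size, since its starting point is a limit and not a number: the limit of > 10000 nM in this assay, at which 2 of the 3 values shown sit.

The change loses the formyl group and adds the methyl on the indole nitrogen in one move, and the compounds shown do not separate these two parts. Also open, going by these compounds, is how this assay would read with an ethyl group in place of that methyl, or with an aminomethyl group in place of the formyl group.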